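Branched ester chain on a retinoid amide: expected inhibition

This account rests on a few compounds, and the source may have more. Where it says the series, first, only, none or still open, it means among the compounds named here.

Measured in a functional assay on NB-4 cells (Homo sapiens) for inhibition, read by MTT assay, with a stated time of 48 h; on this read-out higher numbers stand for weaker inhibition and lower numbers for stronger inhibition:
Compound 2 `CCCC(=O)OCCCCOC(=O)c1ccc(C(=O)Nc2ccc3c(c2)C(C)(C)CCC3(C)C)cc1`: 23200 nM
Compound 3 `Cc1cc2c(cc1C(=O)c1ccc(C(=O)OCCCOC(=O)c3ccc(C(=O)Nc4ccc5c(c4)C(C)(C)CCC5(C)C)cc3)cc1)C(C)(C)CCC2(C)C`: 112000 nM
Compound 1 `C=C(c1ccc(C(=O)NCCCCCCNC(=O)c2ccc(C(=O)Nc3ccc4c(c3)C(C)(C)CCC4(C)C)cc2)cc1)c1cc2c(cc1C)C(C)(C)CCC2(C)C`: only a limit, > 1000000 nM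

Three compounds share the core of compound 2, an amide linked to a tetramethyl-tetrahydronaphthalene and carrying an ester chain on the far benzoate. Compound 2 gives the lower of the two real numbers in this assay; the number for compound 3 stands higher, and the gap lies beyond the usual scatter. The value for compound 1 is a limit of the assay and not a number, so it cannot be ranked (the limit of > 1000000 nM in this assay, at which 1 of the 3 values shown sits).

Compound 4 `CCCC(CCC)C(=O)OCCOC(=O)c1ccc(C(=O)Nc2ccc3c(c2)C(C)(C)CCC3(C)C)cc1` has not been measured. It differs from compound 2 in one place: ((1-propylbutyl)carbonyl)oxy in place of 2-((propylcarbonyl)oxy)ethyl on a saturated chain carbon, two bonds along the chain from an oxygen next to a carbonyl group. The change keeps the ester and the terminal amide intact and rearranges only the chain between the two carbonyls, adding branching at the acyl carbon while shortening the linker.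

Among the measured compounds shown here, with no measured pair that differs in one place, no step can be read directly. A small step, in either direction or none beyond the scatter, is expected, since the anilide and the core that carry the activity in compound 2 are unchanged. Compound 4 is expected to give about 30000 nM, within 9000 nM to 110000 nM. The estimated step of a 1.3-fold higher number from compound 2 to compound 4 (0.11 log units; within the scatter) is therefore taken to be within the scatter.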

Compound 4, half-maximal inhibitory concentration: > 1000000 nM
Compound 4 ended at the assay's limit; the forecaster's own chance of this, stated with the estimate: 10%; middle value at least 33-fold (1.52 log units) away from the limit.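

In this assay compound 4 gives > 1000000 nM, which is a limit of the assay and not a number. Among the compounds shown here, putting ((1-propylbutyl)carbonyl)oxy in place of 2-((propylcarbonyl)oxy)ethyl on this saturated chain carbon gives an at least 43-fold higher number from compound 2 to compound 4 (1.63 log units; beyond the scatter), so this one change in the ester chain, with the amide and the shared core untouched, is enough to carry the read-out from a real number to the limit, something the earlier compounds, with no pair among them differing in one place, could not show. The limit is therefore no longer confined to a single compound of the series: the limit of > 1000000 nM in this assay, at which 2 of the 4 values shown sit.

The true size of the step stays unknown, and the compounds shown do not separate the branching at the acyl carbon from the shortening of the linker, as the two arrive in a single change. Going by these compounds, it also stays open whether an unbranched butanoyl ester on the shorter linker, a longer chain with the same branched acyl group, or a carboxylic acid or an amine at the chain end would give a real number in this assay.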